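This account rests on a few compounds, and the source may have more. Where it says the series, first, only, none or still open, it means among the compounds named here.

Series notes. Compound 1 `Cn1c(=O)c(C(=O)Nc2ccc(Oc3ccncc3-c3cccnc3)c(F)c2)nn(-c2ccc(Cl)cc2)c1=O` and compound 2 `Cn1c(=O)c(C(=O)Nc2ccc(Oc3ccncc3-c3cccnc3)c(F)c2)nn(-c2ccc(F)c(Cl)c2)c1=O` share one core; in a functional assay on HT-29 cells (Homo sapiens) for cytotoxicity, read by MTT assay, with a stated time of 72 h (a lower number here means a stronger inhibitor, a higher number a weaker inhibitor), compound 1 gives 440 nM and compound 2 gives 4780 nM. Within the data shown here, compound 3 `COc1ccc(-n2nc(C(=O)Nc3ccc(Oc4ccncc4-c4cccnc4)c(F)c3)c3ccccc3c2=O)cc1` carries a second core, and in this assay compound 3 gives "not determined" (no result reported), so it stands nowhere on the numbers so far. Compound 4 `O=C(Nc1ccc(Oc2ccncc2-c2cccnc2)c(F)c1)c1nn(-c2ccc(F)cc2)c(=O)c2ccccc12` differs from compound 3 in that (fluoro in place of methoxy on an aromatic carbon), read one bond further out as 4-methoxyphenyl to 4-fluorophenyl. Among the measured compounds shown here, no measured step covers this exact change on this core; the only comparable information is an 11-fold higher number from compound 1 to compound 2 (1.04 log units; beyond the scatter), which shows that this assay responds strongly to substitution on the phenyl attached to the ring nitrogen. Direction and size for compound 4 therefore remain open. Compound 4 is expected to fall near 800 nM, between 150 nM and 5000 nM.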

Compound 4, half-maximal inhibitory concentration: 990 nM
The estimate for compound 4 lay 1.2-fold (0.09 log units) below the measured number, and the stated range covers the measured number.
By their numbers in this assay, from the lowest: compound 1; then compound 4; then compound 2.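

No new step can be read from compound 4 in this assay: its counterpart, compound 3, carries no number. The compounds shown leave open how 4-methoxyphenyl to 4-fluorophenyl shifts potency on this core. Nothing shown offers an explanation.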